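The compounds below may be only part of what the source reports. "The series", "measured", "known", "first", "only" and "open" are said of these compounds alone.

In a functional assay on DU-145 cells (Homo sapiens) for inhibition, read by MTT assay, with stated times of 18 h and 4 h (on this read-out lower numbers stand for stronger inhibition and higher numbers for weaker inhibition), compound 1 `CCCCCCCCOP(=O)(O)OCCSC(=S)N1CCCCC1` reads > 100000 nM, which is a limit of the assay and not a number. For the measured compounds named here, compound 2 `CCCCCCCCCCOP(=O)(O)OCCSC(=S)N1CCN(C)CC1` gives 82300 nM, the only actual number so far. Compound 3 `CCCCCCCCCCOP(=O)(O)OCCSC(=S)N1CCCCC1` carries piperidin-1-yl in place of 4-methylpiperazin-1-yl on a thiocarbonyl carbon. Going by the values given here, no measured pair isolates this change, so no shift beyond the scatter of this assay is expected. The expected move is a 1.1-fold lower number from compound 2 to compound 3 (0.04 log units; within the scatter), an estimate that leaves the direction unresolved. For compound 3, the expected value is 75000 nM, with an estimated range of 35000 nM to 100000 nM.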

Compound 3, half-maximal inhibitory concentration: 29300 nM
The estimate for compound 3 lay 2.6-fold (0.41 log units) above the measured number; measured number outside the range, below it.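

In this assay, the group on the thiocarbonyl carbon proves to matter: piperidin-1-yl in place of 4-methylpiperazin-1-yl gives a 2.8-fold lower number from compound 2 to compound 3 (0.45 log units; beyond the scatter). Ethyl in place of hydrogen on a saturated chain carbon also counts, giving an at least 3.4-fold lower number from compound 1 to compound 3 (0.53 log units; beyond the scatter). Compound 1 stands at a limit, so that step gives only a bound: the limit of > 100000 nM in this assay, at which 1 of the 3 values shown sits.

Going by these compounds, whether the two changes act independently of each other remains open. Also open, on these data alone, is whether morpholin-4-yl on the thiocarbonyl carbon, or a longer chain on the shared core, would read lower still.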